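Removing the tert-butyl from a cyanoaziridine urea

The compounds below may be only part of what the source reports. "The series", "measured", "known", "first", "only" and "open" are said of these compounds alone.

Measured compounds:
compound 1 `CCCCNC(=O)N1CC1C#N` 12000 nM
compound 2 `CC(C)(C)NC(=O)N1CC1C#N` 457000 nM
compound 3 `CCOC(=O)c1ccc(NC(=O)N2CC2C#N)cc1` 9700 nM

In a functional assay on L1210 cells (Mus musculus) for inhibition, read by MTT assay (on this read-out higher numbers stand for weaker inhibition and lower numbers for stronger inhibition), compound 2 gives the highest number of the three, with compound 1 at 12000 nM and compound 3 at 9700 nM both far lower. Compound 4 `N#CC1CN1C(N)=O` differs from compound 2 by hydrogen in place of tert-butyl on an amide-type nitrogen. Among the measured compounds shown here, the one step that bears on this change is a 38-fold higher number from compound 1 to compound 2 (1.58 log units; beyond the scatter), where branching on the same nitrogen raised the number sharply; the data hold no step in which the nitrogen substituent is removed altogether. Given that the bulky group is what set compound 2 apart, compound 4 is expected to move back toward the numbers of the other compounds, with a 15-fold lower number from compound 2 to compound 4 (1.18 log units; beyond the scatter) as the expected step, though the uncertainty is wide. Compound 4 is estimated at 30000 nM, in the range 4000 nM to 250000 nM.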

Compound 4, half-maximal inhibitory concentration: > 90000 nM
Compound 4 ended at the assay's limit; the forecaster's own chance of this, stated with the estimate: 10%; at least 3.0-fold (0.47 log units) between middle value and limit.
By their numbers in this assay, from the lowest: compounds 3 and 1 (each within the scatter of the next); then compound 2.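

In this assay compound 4 stands at a limit of the assay, not at a readable number: the limit of > 90000 nM in this assay, at which 1 of the 4 values shown sits. Hydrogen in place of butyl on an amide-type nitrogen gives an at least 7.5-fold higher number from compound 1 to compound 4 (0.87 log units; beyond the scatter), so removing the substituent altogether does not return the number to the level of compound 1. The step from compound 2 to compound 4 cannot be read, so hydrogen and tert-butyl cannot be ranked against each other here.

The compounds shown leave open how a hexyl chain, a cyclohexyl ring or a benzyl group on this nitrogen would compare with the butyl of compound 1.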